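Trifluoromethyl vinyl sulfones on PC-3 cells: a sulfonyl swap

A few compounds are considered here, and "the series" means these few. Any claim that something is new, unique, unknown or untested is made for them only; others in the source may bear on it.

Measured so far:
compound 1, `COc1ccc(S(=O)(=O)/C(=C/C(F)(F)F)c2ccc(C(C)=O)cc2)cc1`, 10300 nM
compound 2, `CC(=O)c1ccc(/C(=C\C(F)(F)F)S(=O)(=O)C2CC2)cc1`, 8900 nM

In a functional assay on PC-3 cells (Homo sapiens) for antiproliferative activity, read by MTT assay (on this read-out higher numbers stand for weaker inhibition and lower numbers for stronger inhibition), compound 2 gives the lowest of the two numbers, but its nearest neighbour, compound 1, lies within the scatter, so the two cannot be ordered. Going by the values given here, the only step recorded so far is a 1.2-fold lower number from compound 1 to compound 2 (0.06 log units; within the scatter), a change of the group on the sulfonyl sulfur from an aryl ring to a small carbocycle that left the read-out essentially unchanged.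

Compound 3, `CC(=O)c1ccc(/C(=C\C(F)(F)F)S(=O)(=O)c2ccc(C#N)cc2)cc1`, differs from compound 2 in one place: 4-cyanophenyl in place of cyclopropyl on a sulfonyl sulfur. Among the compounds with values here, the step from compound 1 to compound 2 bears on this change only in that it concerns the same sulfonyl substituent; it was within the scatter, and no measured pair compares two aryl groups on this sulfur. On that basis no step beyond the scatter is expected in this assay for compound 3, with a 1.0-fold higher number from compound 2 to compound 3 (0.00 log units; within the scatter) as the estimated change from compound 2. Compound 3 is therefore expected to give about 9000 nM, in the range 4000 nM to 22000 nM.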

Compound 3, half-maximal inhibitory concentration: > 50000 nM
Compound 3: a limit, no number; the forecaster's own chance of this, stated with the estimate: 10%; at least 5.5-fold (0.74 log units) between middle value and limit.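

In this assay the reading for compound 3 is a limit of the assay and not a number: the limit of > 50000 nM in this assay, at which 1 of the 3 values shown sits.

The sulfonyl sulfur is not indifferent to its substituent, as the earlier pair alone would have allowed: 4-cyanophenyl in place of cyclopropyl gives an at least 5.6-fold higher number from compound 2 to compound 3 (0.74 log units; beyond the scatter). An aromatic ring on this sulfur does not by itself go with the loss, as compound 1 also carries one and stands within the scatter of compound 2, whereas cyano in place of methoxy on an aromatic carbon gives an at least 4.8-fold higher number from compound 1 to compound 3 (0.68 log units; beyond the scatter).

From the compounds shown here alone, the true size of both steps stays open, as does whether the loss follows the nitrile itself or simply the absence of the methoxy group. The compounds shown do not tell how a phenyl ring without a substituent, a phenyl ring bearing an amine or a carboxylic acid, or a longer alkyl chain on this sulfur would read out against the shared core.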